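A 4-fluorophenyl swap on compound 2

The source may hold more compounds than are shown below. What is called first, only, known or untested is meant among the compounds shown, and "the series" means these compounds.

In a toxicity assay on HepG2 2.2.15 cells (Homo sapiens) for cytotoxicity, read by CellTiter-Glo (on this read-out higher numbers stand for lower toxicity in this test and lower numbers for higher toxicity in this test), compound 1 (`O=C1CC(Oc2ncccn2)CN1c1cnn2c1CN(C(=O)Nc1cc(F)c(F)c(F)c1)C(C1CC1)C2`) gives > 200000 nM as a limit of the assay, not a number. Going by the values given here, compound 2 (`O=C1CC(c2cnco2)CN1c1cnn2c1CN(C(=O)Nc1cc(F)c(F)c(F)c1)C(C1CC1)C2`) gives 139000 nM as the only actual number so far. Compound 3 (`O=C1CC(c2ccc(F)cc2)CN1c1cnn2c1CN(C(=O)Nc1cc(F)c(F)c(F)c1)C(C1CC1)C2`) carries 4-fluorophenyl in place of 1,3-oxazol-5-yl on a saturated ring carbon. Among the compounds with values here, one measured step touches that carbon, an at least 1.4-fold lower number from compound 1 to compound 2 (0.15 log units; that floor lies within the scatter) and it stays within the scatter, so no change beyond the scatter is expected. The expected step is a 1.3-fold lower number from compound 2 to compound 3 (0.10 log units; within the scatter) in this assay and could go unnoticed. For compound 3 the estimated value is 110000 nM with an expected range from 50000 nM to 200000 nM in this assay.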

Compound 3, half-maximal cytotoxic concentration: 32100 nM
Compound 3: middle estimate off by 3.4-fold (0.53 log units), on the high side; the whole stated range lies above it.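

This saturated ring carbon can move the read-out after all. In this assay, 4-fluorophenyl in place of 1,3-oxazol-5-yl gives a 4.3-fold lower number from compound 2 to compound 3 (0.64 log units; beyond the scatter), so toxicity in this test rises, and in place of (pyrimidin-2-yl)oxy it gives an at least 6.2-fold lower number from compound 1 to compound 3 (0.79 log units; beyond the scatter). Compound 1 stands at a limit of the assay, not a number: the limit of > 200000 nM in this assay, at which 1 of the 3 values shown sits.

The compounds shown do not separate the part played by the fluorine from that of the carbon-only ring. As far as these compounds go, how a plain phenyl, an amine or a carboxylic acid on this carbon would read also remains open.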